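This account rests on a few compounds, and the source may have more. Where it says the series, first, only, none or still open, it means among the compounds named here.

Measured compounds: compound 1 `COc1ccc(/C=C/C2CC(=O)C=CO2)cc1` gives 152 uM in a functional assay on U-251 cells (Homo sapiens) for inhibition, read by sulforhodamine B assay, with a stated time of 48 h; a lower number here means a stronger inhibitor of growth, a higher number a weaker inhibitor of growth; compound 2 `COc1ccc(/C=C/C2CC(=O)C=CO2)cc1OC` gives 86.9 uM in this assay; compound 3 `O=c1ccoc(/C=C/c2ccccc2)c1` gives 285 uM in this assay.

Within the data shown here, the one measured step on one core is a 1.7-fold lower number from compound 1 to compound 2 (0.24 log units; within the scatter), the change being (methoxy in place of hydrogen on an aromatic carbon). Compound 4 `COc1ccc(/C=C/c2cc(=O)cco2)cc1` is to be measured; it differs from compound 3 by methoxy in place of hydrogen on an aromatic carbon. The difference between the cores of compound 1 and compound 3 is not broken down here. The two changes are of the same kind, methoxy in place of hydrogen on an aromatic carbon, but not the same: in compound 2 the entering group sits ortho to a methoxy group and meta to a group of 9 heavy atoms, whereas in compound 4 it sits para to a group of 9 heavy atoms, with no other methoxy on the ring.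

For compound 4 a step of a 1.7-fold lower number from compound 3 to compound 4 (0.22 log units; within the scatter) is expected, a modest lowering, resting on the earlier step of the same kind from compound 1 to compound 2 being within the scatter. Compound 4 is estimated at 170 uM, between 80 uM and 350 uM.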

Compound 4, concentration for growth inhibition (reported as GI): 278 uM
The estimate for compound 4 lay 1.6-fold (0.21 log units) below the measured number; measured number inside the range.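

In this assay, methoxy in place of hydrogen on an aromatic carbon gave a 1.0-fold lower number from compound 3 to compound 4 (0.01 log units; within the scatter), so on this core the change left the number unmoved within the scatter. The two steps of this change do not differ beyond the scatter, and the compounds give no sign that it behaves differently from one core to the other: the same change on two cores in this assay, a 1.7-fold lower number (0.24 log units; within the scatter) from compound 1 to compound 2 and a 1.0-fold lower number (0.01 log units; within the scatter) from compound 3 to compound 4, 1.7-fold (0.23 log units) apart, within the scatter of two such steps Neither step lies beyond the scatter, however, so this agreement shows no measured effect of methoxy that could be carried across, and it cannot show that the change would transfer once a real effect appeared.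

The compounds shown leave open whether another group on the aromatic ring, such as an amine, a carboxylic acid or a longer alkoxy chain, would move the number beyond the scatter on either core. They also leave open whether a second methoxy on compound 4 would give the same step as on the core of compound 1.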